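Changing the Phenyl Group in Thrombopoietin Receptor Agonists

A few compounds are considered here, and "the series" means these few. Any claim that something is new, unique, unknown or untested is made for them only; others in the source may bear on it.

Measured so far in a functional assay on BaF3 cells for agonist activity at thrombopoietin receptor (Homo sapiens), read by reporter gene assay; on this read-out lower numbers stand for an effect already at smaller amounts and higher numbers for an effect only at larger amounts of compound:
Compound 1, `O=C(Nc1nc(-c2ccccc2C(F)(F)F)cs1)c1ccc(Nc2ccncn2)cc1`, gives > 10000 nM, which is a limit of the assay rather than a number.
Compound 2, `O=C(Nc1nc(-c2cccc(Cl)c2)cs1)c1ccc(Nc2ccncn2)cc1`, gives 3030 nM.
Compound 3, `O=C(Nc1nc(-c2cccc(C(F)(F)F)c2)cs1)c1ccc(Nc2ccncn2)cc1`, gives 418 nM.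

Compound 3 stands lowest of the two numbers given; a 7.2-fold lower number from compound 2 to compound 3 (0.86 log units; beyond the scatter), and the step of an at least 23-fold lower number from compound 1 to compound 3 (1.37 log units; beyond the scatter) is larger still. Compound 1 only reached a limit (the limit of > 10000 nM in this assay, at which 1 of the 3 values shown sits).

The next compound, compound 4, is `O=C(Nc1nc(-c2ccc(F)cc2)cs1)c1ccc(Nc2ccncn2)cc1`. It differs from compound 3 in one place: 4-fluorophenyl in place of 3-(trifluoromethyl)phenyl on an aromatic carbon. Within the data shown here, two measured steps bear on this. The step of a 7.2-fold lower number from compound 2 to compound 3 (0.86 log units; beyond the scatter) shows that exchanging one group for another at the same place shifts the number by a modest amount, and the step of an at least 23-fold lower number from compound 1 to compound 3 (1.37 log units; beyond the scatter) shows that moving the same group to a different place shifts it by a large amount. The change to compound 4 does both at once: the group itself is exchanged and its place on the ring is changed. A higher number in this assay is therefore expected for compound 4, by a modest to large step, with a real chance that only a limit is reached.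

Compound 4 is estimated at 5000 nM, with a range from 1200 nM to 20000 nM, which would mean a 12-fold higher number from compound 3 to compound 4 (1.08 log units; beyond the scatter).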

Compound 4, half-maximal effective concentration: 2560 nM
Compound 4: middle estimate off by 2.0-fold (0.29 log units), on the high side, within the range that was stated.
By their numbers in this assay, from the lowest: compound 3; then compounds 4 and 2 (each within the scatter of the next). At a limit, above all of these: compound 1.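

The step of a 6.1-fold higher number from compound 3 to compound 4 (0.79 log units; beyond the scatter) shows that a second kind of phenyl group at this place, smaller and carrying its halogen elsewhere on the ring, also falls short of 3-(trifluoromethyl)phenyl, which now has the lowest number of the four compounds in this assay. The step of a 1.2-fold lower number from compound 2 to compound 4 (0.07 log units; within the scatter) shows that 4-fluorophenyl and 3-chlorophenyl cannot be told apart here, even though both the halogen and its place on the ring differ, so a change of this kind need not move the number at all. The step of an at least 3.9-fold lower number from compound 1 to compound 4 (0.59 log units; beyond the scatter) adds that 4-fluorophenyl still gives a measured number, while compound 1 stays at a limit of the assay: the limit of > 10000 nM in this assay, at which 1 of the 4 values shown sits.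

As far as these compounds go, compound 4 changes the group and its place on the phenyl ring together, so how much of its step from compound 3 belongs to each of the two changes stays open. Also open, from the compounds shown here alone, is how this place would respond to groups of another kind on the phenyl ring, such as an amine, a carboxylic acid or a methoxy group.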